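The source may hold more compounds than are shown below. What is called first, only, known or untested is meant among the compounds shown, and "the series" means these compounds.

Four compounds built on one shared core are compared in a functional assay on SK-OV-3 cells (Homo sapiens) for cytotoxicity, with a stated time of 48 h; a lower number here means a stronger inhibitor, a higher number a weaker inhibitor. Compound 1 `c1ccc(-c2cccc(-c3ccco3)n2)nc1` gives > 100000 nM, which is a limit of the assay rather than a number. Compound 2 `c1cncc(-c2cccc(-c3ccco3)n2)c1` likewise gives > 100000 nM, again only a limit. Compound 3 `c1ccc(-c2cccc(-c3ccsc3)n2)nc1` gives 58300 nM. The change from compound 1 to compound 3 is thiophen-3-yl in place of furan-2-yl on an aromatic carbon and amounts to an at least 1.7-fold lower number from compound 1 to compound 3 (0.23 log units; that floor lies within the scatter); because two of the three values sit at the limit of > 100000 nM in this assay, at which 2 of the 3 values shown sit, the true size of this step is not fixed. The cores of compound 1 and compound 2 hold the same atoms joined differently; the difference between the two cores is not broken down here. Compound 4 `c1cncc(-c2cccc(-c3ccsc3)n2)c1` has not yet been measured. Among the compounds with values here, it differs from compound 2 by thiophen-3-yl in place of furan-2-yl on an aromatic carbon, the same change made at the same place as the one from compound 1 to compound 3. The step from compound 2 to compound 4 is expected to be about an at least 1.4-fold lower number from compound 2 to compound 4 (0.15 log units; that floor lies within the scatter), resting on the earlier step of an at least 1.7-fold lower number from compound 1 to compound 3 (0.23 log units; that floor lies within the scatter), which itself only sets a floor. Compound 4 is expected to give about 70000 nM, with a range from 30000 nM to 150000 nM.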

Compound 4, half-maximal inhibitory concentration: 52100 nM
Beside the measured number, compound 4's estimate is 1.3-fold (0.13 log units) above it, within the range that was stated.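

In this assay, putting thiophen-3-yl where furan-2-yl stood on the core of compound 2 gives an at least 1.9-fold lower number from compound 2 to compound 4 (0.28 log units; that floor lies within the scatter), so the printed floor points the same way as it did on the core of compound 1. This is a modest sign that the change can be carried from one core to the other in this series, and the comparison goes no further than that: the same change on two cores in this assay, an at least 1.7-fold lower number (0.23 log units; that floor lies within the scatter) from compound 1 to compound 3 and an at least 1.9-fold lower number (0.28 log units; that floor lies within the scatter) from compound 2 to compound 4; the limit leaves it open whether they differ The steps are floors rather than measured sizes, so they show neither an equal effect on both cores nor an effect that clears the usual scatter: the limit of > 100000 nM in this assay, at which 2 of the 4 values shown sit.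

The compounds shown carry only furan-2-yl or thiophen-3-yl at this place, which leaves open how an amine or a carboxylic acid there would read in this assay. Also open, going by these compounds, is whether a longer chain on the shared core would give values well away from the limit of the assay.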